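Chloro in place of pyrrolidin-1-yl: notes on compound 4

The source may report more compounds than this note shows. Statements on the series, on what has been measured and on what is new or still open speak of the compounds shown alone.

Measured so far:
Compound 1, `CC(=O)c1ccccc1-c1nc2cc([N+](=O)[O-])ccc2[nH]1`. In a functional assay for antagonist activity at Neuropeptides B/W receptor type 1 (Homo sapiens), read by cAMP accumulation (a higher number here means a weaker inhibitor, a lower number a stronger inhibitor), compound 1 gives > 31600 nM, a limit of the assay rather than a number.
Compound 2, `CC(=O)c1cccc(-c2nc3cc([N+](=O)[O-])ccc3[nH]2)c1`. In this assay compound 2 gives > 31600 nM, again a limit.
Compound 3, `O=[N+]([O-])c1ccc2[nH]c(-c3cccc(N4CCCC4)c3)nc2c1`. In this assay compound 3 gives 6010 nM.

Among the measured compounds shown here, compound 3 thus carries the only number in the set; the other two values sit at the limit of > 31600 nM in this assay, at which 2 of the 3 values shown sit. For the measured compounds named here, the single step that can be read is an at least 5.2-fold lower number from compound 2 to compound 3 (0.72 log units; beyond the scatter), so the pyrrolidin-1-yl group accompanies the one measurable result.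

Compound 4, `O=[N+]([O-])c1ccc2[nH]c(-c3cccc(Cl)c3)nc2c1`, is the next one to be run. It differs from compound 3 in one place: chloro in place of pyrrolidin-1-yl on an aromatic carbon.

Going by the values given here, no measured step involves a chloro group, so nothing bears on the entering group directly. What bears on the step is the leaving group: the step from compound 2 to compound 3 shows that installing pyrrolidin-1-yl brought the value down from a limit, and compound 4 now loses that group. The expectation is therefore a clear rise in this assay, back toward the limit region, with a fair chance that only a limit is returned.

For compound 4 the estimate is 20000 nM, within 6000 nM to 60000 nM, which means an expected step of a 3.3-fold higher number from compound 3 to compound 4 (0.52 log units; beyond the scatter).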

Compound 4, half-maximal inhibitory concentration: 9980 nM
Beside the measured number, compound 4's estimate is 2.0-fold (0.30 log units) above it, within the range that was stated.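

In this assay, the pyrrolidin-1-yl group proves not to be needed for a measurable number at this position: chloro in its place gives a 1.7-fold higher number from compound 3 to compound 4 (0.22 log units; within the scatter), so the two groups cannot be told apart here despite their difference in size and ring content. Chloro in place of acetyl on the aromatic carbon gives an at least 3.1-fold lower number from compound 2 to compound 4 (0.50 log units; beyond the scatter), so at this position, meta to a large group, acetyl is the group that stands apart from the other two, and the gain seen earlier with pyrrolidin-1-yl is not specific to that group. The value of compound 2 is a limit and not a number, so the true size of that step stays open: the limit of > 31600 nM in this assay, at which 2 of the 4 values shown sit.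

Going by these compounds, with only chloro and pyrrolidin-1-yl giving numbers at this carbon, it remains open whether a primary amine, a methoxy group or a carboxylic acid there would give a value of the same order or fall to the limit. The compounds shown also leave open whether replacing the nitro group on the shared core would move the number beyond the scatter.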